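Fluoro for methoxy on the aryl of compound 3

The source may report more compounds than this note shows. Statements on the series, on what has been measured and on what is new or still open speak of the compounds shown alone.

Going by the values given here, compound 3 `COc1ccc(-c2cc(NNC(=O)Nc3cc(Cl)nc(Cl)c3)nc3c2cnn3C)cc1` stands lowest of the three numbers so far: in a functional assay on HCT-116 cells (Homo sapiens) for cytotoxicity, read by MTT assay, with a stated time of 48 h, in the presence of a further agent that is not named here (a higher number here means that more compound is needed for the effect, a lower number that less compound is needed), compound 3 gives 12300 nM. Compound 1 `CCN(CC)c1cc(NC(=O)NNc2cc(-c3ccc(F)cc3)c3cnn(C)c3n2)cc(Cl)n1` is nearest, and in this assay compound 1 gives 29400 nM. Compound 2 `CCCc1cc(NNC(=O)Nc2cc(Cl)nc(Cl)c2)nc2c1cnn2C` is furthest; in this assay compound 2 gives 76200 nM. Among the compounds with values here, the only step measured across a single change is a 6.2-fold lower number from compound 2 to compound 3 (0.79 log units; beyond the scatter).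

Compound 4 `Cn1ncc2c(-c3ccc(F)cc3)cc(NNC(=O)Nc3cc(Cl)nc(Cl)c3)nc21` differs from compound 3 by fluoro in place of methoxy on an aromatic carbon, the same difference read one bond further out being 4-methoxyphenyl to 4-fluorophenyl. Within the data shown here, no measured step bears directly on this change. Among the measured compounds shown here, compound 1 carries the same 4-fluorophenyl but differs from compound 4 elsewhere as well, so its value and that of compound 3 show only that a fluorophenyl analogue can sit higher. The step between compound 2 and compound 3 concerns the aryl as a whole, not the group on it. The expected step is therefore a 1.5-fold higher number from compound 3 to compound 4 (0.17 log units; within the scatter), a small shift upward near the scatter. Compound 4 is expected at 18000 nM, with a range of 6000 nM to 50000 nM.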

Compound 4, half-maximal effective concentration: 8210 nM
Beside the measured number, compound 4's estimate is 2.2-fold (0.34 log units) above it; low and high end bracket the measured number.
By their numbers in this assay, from the lowest: compounds 4 and 3 (each within the scatter of the next); then compound 1; then compound 2.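

Working notes: at the position on the aryl described as para to a large group, fluoro and methoxy are not told apart in this assay, with a 1.5-fold lower number from compound 3 to compound 4 (0.18 log units; within the scatter) as the reading for this change. The aryl itself therefore matters more here than the group it carries: a 9.3-fold lower number from compound 2 to compound 4 (0.97 log units; beyond the scatter) stands with 4-fluorophenyl in place of propyl, in line with a 6.2-fold lower number from compound 2 to compound 3 (0.79 log units; beyond the scatter) for 4-methoxyphenyl. A second site also becomes readable, since chloro in place of diethylamino on an aromatic carbon gives a 3.6-fold lower number from compound 1 to compound 4 (0.55 log units; beyond the scatter) as a step beyond the scatter.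

Nothing available explains any of these steps. Open, from the compounds shown here alone, is whether an amine or a carboxylic acid on the aryl, or a longer chain in place of propyl, would shift the number beyond the scatter.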